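This account rests on a few compounds, and the source may have more. Where it says the series, first, only, none or still open, it means among the compounds named here.

Measured compounds in an ADME assay on Vero cells (Chlorocebus sabaeus) for cytotoxicity, with a stated time of 72 h; on this read-out higher numbers stand for weaker inhibition and lower numbers for stronger inhibition:
compound 1, `O=[N+]([O-])c1cn2c(n1)OC[C@@H](OCc1ccc(-c3ccc(C(F)(F)F)cc3)s1)C2`, gives > 128000 nM, a limit of the assay.
compound 2, `O=[N+]([O-])c1cn2c(n1)OC[C@@H](OCc1ccc(-c3ccc(F)cc3)s1)C2`, gives > 128000 nM, again a limit of the assay.

Compound 2 therefore stands at the limit in this assay, with no number of its own; the other value shown is a limit as well, so there is nothing to rank it against. Within the data shown here, the one measured step, a step that the two limits leave unreadable from compound 1 to compound 2, cannot be read for size, as both ends sit at the same limit, (the limit of > 128000 nM in this assay, at which 2 of the 2 values shown sit).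

Compound 3, `O=[N+]([O-])c1cn2c(n1)OC[C@@H](OCc1ccc(-c3cncc(F)c3)s1)C2`, differs from compound 2 by 5-fluoropyridin-3-yl in place of 4-fluorophenyl on an aromatic carbon. Among the measured compounds shown here, the only comparable step gives no readable size, so no movement beyond the scatter is expected in this assay; compound 3 is expected to remain at the limit, the step that the limit leaves unreadable from compound 2 to compound 3 being an estimate that reflects this. For compound 3 the estimate in this assay is 180000 nM, between 64000 nM and 500000 nM.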

Compound 3, half-maximal inhibitory concentration: > 128000 nM
Compound 3 gave a limit, no number (the forecaster's own chance of this, stated with the estimate: 85%); the middle value is on the limit's open side.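

No new step can be read in this assay between compound 2 and compound 3, as both sit at the assay limit: the limit of > 128000 nM in this assay, at which 3 of the 3 values shown sit.

The compounds shown leave open how far each lies from that limit, and so whether 5-fluoropyridin-3-yl and 4-fluorophenyl differ at all on this read-out.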